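A Hydroxy Group Enters Where a Methoxy Once Sat

The compounds below may be only part of what the source reports. "The series", "measured", "known", "first", "only" and "open" are said of these compounds alone.

For the measured compounds named here, compound 1 `COc1ccc(N2CCN(CCC(OC(N)=O)c3ccc(F)cc3)CC2)cc1` gives 12.4 mg/kg in a functional assay on the whole organism for inhibition, with Mus musculus as the target, in the writhing test, with a stated time of 1 h (a higher number here means that more compound is needed for the effect, a lower number that less compound is needed), while compound 2 `NC(=O)OC(CCN1CCN(c2ccccc2)CC1)c1ccc(F)cc1` gives 2.79 mg/kg, the lowest of the two numbers so far. Going by the values given here, the one measured step, a 4.4-fold lower number from compound 1 to compound 2 (0.65 log units; beyond the scatter), removed a methoxy from an aromatic carbon. Compound 3 `NC(=O)OC(CCN1CCN(c2ccc(O)cc2)CC1)c1ccc(F)cc1` reverses direction at that same position: hydroxy in place of hydrogen on an aromatic carbon. Since placing a group there previously raised the number, a modest rise is expected for compound 3, estimated at a 2.0-fold higher number from compound 2 to compound 3 (0.29 log units; within the scatter), though hydroxy is a different group and the size is uncertain. Compound 3 is therefore expected to give about 5.5 mg/kg, plausibly between 2 mg/kg and 15 mg/kg.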

Compound 3, dose for half-maximal effect: 7.24 mg/kg
The estimate for compound 3 lay 1.3-fold (0.12 log units) below the measured number, within the range that was stated.
By their numbers in this assay, from the lowest: compound 2; then compounds 3 and 1 (each within the scatter of the next).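

In this assay, hydroxy on this ring carbon also raises the number (a 2.6-fold higher number from compound 2 to compound 3 (0.41 log units; beyond the scatter)), so compound 2, with plain hydrogen there, now has a lower number than both oxygen-bearing compounds. Hydroxy and methoxy cannot be told apart at this position (a 1.7-fold lower number from compound 1 to compound 3 (0.23 log units; within the scatter)), which means that removing the methyl from the oxygen has no clear effect. No measurement at hand explains these results. As far as these compounds go, it remains open whether a group without oxygen, such as an amine or a chlorine atom, would also raise the number. From the compounds shown here alone, it also remains open whether any group here could give a lower number than compound 2.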